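Trimming the amide nitrogen: from pyrazolyl to methoxy

A few compounds are considered here, and "the series" means these few. Any claim that something is new, unique, unknown or untested is made for them only; others in the source may bear on it.

Compound 1 `Cc1ccc(OCC(=O)N(Cc2cccs2)c2ccn(C)n2)cc1`: 855 nM
Compound 2 `CCN(Cc1cccnc1)C(=O)COc1ccc(C)cc1`: 15400 nM

In an assay on HEK293 cells for agonist activity at transient receptor potential cation channel subfamily M member 8 (Homo sapiens), read by fluorescence and calcium flux, with a stated time of 15 min (a lower number here means that less compound is needed, a higher number that more compound is needed for the effect), compound 1 gives 855 nM, the lowest of the two numbers, while compound 2 gives 15400 nM, a gap that lies beyond the scatter. Compound 3 `CON(Cc1cccs1)C(=O)COc1ccc(C)cc1` has not yet been measured. It differs from compound 1 by methoxy in place of 1-methyl-1H-pyrazol-3-yl on an amide-type nitrogen. For the measured compounds named here, no step between measured compounds isolates this change, so the expectation rests on the two values shown. The step from compound 1 to compound 3 is estimated at a 5.8-fold higher number from compound 1 to compound 3 (0.77 log units; beyond the scatter), a rise in this assay. Compound 3 is expected to give 5000 nM, within 1500 nM to 20000 nM.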

Compound 3, half-maximal effective concentration: 10 nM
Beside the measured number, compound 3's estimate is 500-fold (2.70 log units) above it, outside the stated range (below it).
By their numbers in this assay, from the lowest: compound 3; then compound 1; then compound 2.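

In this assay, the substituent on this amide-type nitrogen turns out to matter greatly: methoxy in place of 1-methyl-1H-pyrazol-3-yl gives an 86-fold lower number from compound 1 to compound 3 (1.93 log units; beyond the scatter) and thus a large gain. The five-membered aromatic ring is therefore not needed at this place for a low number, and the smaller methoxy does better with the rest of compound 1 unchanged. Nothing measured here explains the size of this step. Whether the gain is particular to methoxy stays open, since the compounds shown do not include hydroxy, ethoxy or a plain methyl on this nitrogen.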